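Series notes: aryl groups on the core of compound 1

The compounds below may be only part of what the source reports. "The series", "measured", "known", "first", "only" and "open" are said of these compounds alone.

Compound 1 `Clc1ccc2c(NCc3ncc[nH]3)ccnc2c1` is the parent of this set. Among the measured compounds shown here, in a physicochemical assay for lipophilicity, measured as octanol-water partition, at pH 7.4 (a lower number here means a more polar compound, a higher number a more lipophilic compound), compound 1 gives 2.39, the lowest of the three numbers so far. Compound 2 `Fc1ccc(-c2c[nH]c(CNc3ccnc4cc(Cl)ccc34)n2)cc1` gives 4.93 and compound 3 `CN(C)c1ccc(-c2c[nH]c(CNc3ccnc4cc(Cl)ccc34)n2)cc1` gives 4.75. The two measured steps from the parent are both large: a number 2.54 log units higher from compound 1 to compound 2 (beyond the scatter) and a number 2.36 log units higher from compound 1 to compound 3 (beyond the scatter). Between the two aryl analogues the change is small, a number 0.18 log units lower from compound 2 to compound 3 (within the scatter), so the kind of group on the phenyl ring has mattered little here.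

Compound 4 `CN(C)c1cccc(-c2c[nH]c(CNc3ccnc4cc(Cl)ccc34)n2)c1` is not yet measured. Relative to compound 1 the change is 3-(dimethylamino)phenyl in place of hydrogen on an aromatic carbon. For the measured compounds named here, the steps that bear on it are those from compound 1 to compound 2 and from compound 1 to compound 3, both adding a substituted phenyl ring of the same size, and the closest is compound 3, which carries the same dimethylamino group. A large upward step is therefore expected, of about a number 2.31 log units higher from compound 1 to compound 4 (beyond the scatter), close to what compound 3 shows with 4.75. The estimate for compound 4 in this assay is 4.7, with a range from 4.3 to 5.1.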

Compound 4, distribution coefficient: 5.48
Compound 4: the middle estimate sits 0.78 log units below what was measured; the whole stated range lies below it.
By their numbers in this assay, from the lowest: compound 1; then compounds 3 and 2 (each within the scatter of the next); then compound 4.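

In this assay, 3-(dimethylamino)phenyl in place of 4-(dimethylamino)phenyl gives a number 0.73 log units higher from compound 3 to compound 4 (beyond the scatter) on the same aromatic carbon, so the place of the dimethylamino group on the phenyl ring matters, which compound 2 and compound 3 alone could not show. The same group gives a number 0.55 log units higher from compound 2 to compound 4 (beyond the scatter) and, against the parent, a number 3.09 log units higher from compound 1 to compound 4 (beyond the scatter) as the largest step from compound 1 so far, while compound 2 and compound 3 remain within the scatter of each other. No measured evidence on hand accounts for this difference.

Going by these compounds, whether the shift belongs to the dimethylamino group or to its place on the phenyl ring remains open. A methoxy group or a carboxylic acid in the place held by dimethylamino in compound 4 would bear on that question.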